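A few compounds are considered here, and "the series" means these few. Any claim that something is new, unique, unknown or untested is made for them only; others in the source may bear on it.

In a functional assay on HL-60 cells (Homo sapiens) for antiproliferative activity (on this read-out higher numbers stand for weaker inhibition of growth and lower numbers for stronger inhibition of growth), compound 2 `COC(=O)CCCCCCCCCCCCCC/C=C1\CC(CO)(COC(=O)C(C)(C)C)OC1=O` gives > 10 ug/mL, which is a limit and not a number. Compound 3 `CC(C)(C)C(=O)OCC1(CO)C/C(=C\CCCCCCCCCCCO)C(=O)O1` gives > 10 ug/mL, also a limit. Compound 2 thus stands at the limit of > 10 ug/mL in this assay, at which 2 of the 3 values shown sit. The structural change to compound 4 `CC(C)(C)C(=O)OCC1(CO)C/C(=C\CCCCCCCCCCCCCCC=O)C(=O)O1` is hydrogen in place of methoxy on a carbonyl carbon, turning methoxycarbonyl into formyl. Going by the values given here, the one measured step available is a step that the two limits leave unreadable from compound 2 to compound 3, so it offers no size to carry over. Compound 1 `COCCCCCCCCCCCCCCC/C=C1/CC(CO)(COC(=O)C(C)(C)C)OC1=O`, at 3.97 ug/mL, shows only that this family can give a real number. A modest move towards stronger inhibition of growth is therefore expected, an at least 1.1-fold lower number from compound 2 to compound 4 (0.04 log units; that floor lies within the scatter), and it may not exceed the scatter. Compound 4 is estimated at 9 ug/mL, within a range of 3 ug/mL to 25 ug/mL.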

Compound 4, concentration for 50% growth inhibition: > 10 ug/mL
Compound 4: a limit, no number; the forecaster's own chance of this, stated with the estimate: 55%; middle value at least 1.1-fold (0.04 log units) from the limit.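

Compound 4 gives > 10 ug/mL, a limit and not a number. Its steps from compound 2 and to compound 3, which also sit at limits, cannot be read. Going by these compounds, whether hydrogen in place of methoxy on a carbonyl carbon changes growth inhibition at all stays open.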